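Anilino to Hydroxy on the Shared Purine Core: An Expectation

The source may report more compounds than this note shows. Statements on the series, on what has been measured and on what is new or still open speak of the compounds shown alone.

Compound 1 `c1ccc(Cn2cnc3cncnc32)cc1` and compound 2 `c1ccc(Cn2cnc3c(Nc4ccccc4)ncnc32)cc1` have both been tested in a functional assay on the whole organism for inhibition, with Rattus norvegicus as the target, in the maximal electroshock model, at a dose of 25 mg/kg by the intraperitoneal route; on this read-out higher numbers stand for more inhibition at the one dose given (going by the name of the read-out) and lower numbers for less inhibition. In this assay compound 1 gives 33%, while compound 2 gives 0%. Going by the values given here, compound 2 thus stands lowest of the two measured numbers, with compound 1 as its only neighbour, and the step of a number 33 percentage points lower from compound 1 to compound 2 (beyond the scatter) is a large one. Compound 3 `Oc1ncnc2c1ncn2Cc1ccccc1` is not yet measured; it differs from compound 2 in that (hydroxy in place of anilino on an aromatic carbon). Among the compounds with values here, the one measured step that bears on this change is a number 33 percentage points lower from compound 1 to compound 2 (beyond the scatter), which accompanied anilino entering in place of hydrogen. Hydroxy brings one heavy atom where anilino brought seven, so a partial return toward the number for compound 1 is expected, though no measured compound carries hydroxy here. Compound 3 is therefore expected to give 15%, with a range from 0% to 40%. The expected step is a number 15 percentage points higher from compound 2 to compound 3 (beyond the scatter), upward but uncertain.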

Compound 3, a percentage reported as inhibition, in the whole organism at one dose (the size of the read-out at that dose, not a potency): 17%
The estimate for compound 3 lay 2 percentage points below the measured number, and the stated range covers the measured number.
By their numbers in this assay, from the lowest: compound 2; then compound 3; then compound 1.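

In this assay there is now a second substituent to set against hydrogen at this position: the step of a number 17 percentage points higher from compound 2 to compound 3 (beyond the scatter) shows that a substituent on this aromatic carbon need not bring the read-out to nothing. The step of a number 16 percentage points lower from compound 1 to compound 3 (beyond the scatter) shows that hydroxy still does not match hydrogen, so compound 1 remains the highest of the three. Anilino and hydroxy have equal hydrogen-bond donor and acceptor counts, so those counts do not separate compound 2 from compound 3, although the two groups differ in heavy atoms and in the aromatic ring that leaves with anilino.

No measured evidence accounts for either step.

Going by these compounds, it stays open whether an amine or a methoxy group here would read like hydroxy, and whether a saturated ring joined through nitrogen would read like anilino.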